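A few compounds are considered here, and "the series" means these few. Any claim that something is new, unique, unknown or untested is made for them only; others in the source may bear on it.

Three compounds from this series have been run in an ADME assay on A549 cells (Homo sapiens) for cytotoxicity, read by MTT assay, with a stated time of 72 h; a lower number here means a stronger inhibitor, a higher number a weaker inhibitor. Compound 1 `CC(=O)N1N=C(c2ccc(-n3c(C)ccc3C)cc2)OC1c1ccccc1Cl` gives 206000 nM. Compound 2 `Brc1ccc(-c2nnc(-c3ccc(-n4cccc4)cc3)o2)cc1` gives 264000 nM, and compound 3 `O=C(NNC(=O)c1ccc(-n2cccc2)cc1)c1ccc(Cl)cc1` gives 185000 nM. On the numbers shown, compound 1 sits between the other two: its nearest neighbour is compound 3 and its furthest is compound 2, yet both gaps lie within the usual scatter of this measurement, so the three compounds cannot be told apart in this assay, and none of them can be called stronger or weaker than another.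

Compound 4 `CC(=O)N1N=C(c2ccc(-n3c(C)ccc3C)cc2)OC1c1cccc([N+](=O)[O-])c1` has not yet been measured. It differs from compound 1 in one place, (3-nitrophenyl in place of 2-chlorophenyl on a saturated ring carbon). For the measured compounds named here, no pair of measured compounds differs in a single place, so there is no measured step on which to rest an expectation for this change; what is known is only that all three measured compounds sit close together. Compound 4 is therefore expected to show no step beyond the scatter in this assay, with a 1.0-fold lower number from compound 1 to compound 4 (0.01 log units; within the scatter). For compound 4 the estimated value in this assay is 200000 nM, with a range from 100000 nM to 400000 nM.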

Compound 4, half-maximal inhibitory concentration: 197000 nM
Compound 4: middle estimate off by 1.0-fold (0.01 log units), on the high side; the range from low to high includes it.
By their numbers in this assay, from the lowest: compounds 3, 4, 1 and 2 (each within the scatter of the next).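

For the compounds shown here, this gives the first measured single-place step: in this assay, 3-nitrophenyl in place of 2-chlorophenyl on the saturated ring carbon gives a 1.0-fold lower number from compound 1 to compound 4 (0.02 log units; within the scatter) and so stays within the scatter. At this carbon, next to the ring oxygen, one substituted phenyl group can therefore replace the other, with a different substituent at a different ring position, without a step that can be read in this measurement. No measurement bears on what lies behind this result.

The compounds shown leave open whether an amine or a carboxylic acid on that phenyl ring, or a longer alkyl chain in place of the ring at this carbon, would give a step beyond the scatter. Also open, on these data alone, is what replacing the acetyl group with a hydrogen would do in this assay to the core of compound 1.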